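Benzyl-linked aryl groups on the shared core: next step

A few compounds are considered here, and "the series" means these few. Any claim that something is new, unique, unknown or untested is made for them only; others in the source may bear on it.

Compound 2 `Cn1c(Cc2cccnc2)nc2cc(O[C@H]3CC[C@@H](C(=O)O)CC3)ccc21` gives 141000 nM in an assay on isolated protein for inhibition of Long-chain-fatty-acid--CoA ligase 1 (Homo sapiens), read by mass spectrometry, with a stated time of 90 min, in the presence of a further agent that is not named here (a lower number here means a stronger inhibitor, a higher number a weaker inhibitor), the highest of the two numbers recorded so far; its nearest neighbour is compound 1 `Cn1c(Cc2cccc(C(F)(F)F)c2)nc2cc(O[C@H]3CC[C@@H](C(=O)O)CC3)ccc21`, which gives 190 nM in this assay. Among the measured compounds shown here, the one measured step, a 740-fold higher number from compound 1 to compound 2 (2.87 log units; beyond the scatter), replaced a six-membered carbon-only aromatic ring by one carrying a ring nitrogen and weakened inhibition sharply. Compound 3 `Cc1cccc(COc2nc3cc(O[C@H]4CC[C@@H](C(=O)O)CC4)ccc3n2C)c1` is not yet measured; it differs from compound 2 by (3-methylbenzyl)oxy in place of (pyridin-3-yl)methyl on an aromatic carbon, so a carbon-only aromatic ring returns, now carried on an oxygen rather than a saturated chain carbon. For the measured compounds named here, the measured step bears on this change in reverse: the return from a nitrogen-containing ring to a carbon-only ring is expected to recover most of the loss seen from compound 1 to compound 2, though no measured pair shows the effect of the oxygen linker or of methyl in place of trifluoromethyl. Compound 3 is therefore estimated at 500 nM, range 100 nM to 4000 nM, a step of a 280-fold lower number from compound 2 to compound 3 (2.45 log units; beyond the scatter).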

Compound 3, half-maximal inhibitory concentration: 17000 nM
For compound 3 the middle estimate is 34-fold (1.53 log units) below the measured one, outside the stated range (above it).
By their numbers in this assay, from the lowest: compound 1; then compound 3; then compound 2.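

In this assay, a carbon-only aromatic ring at this position gives only a partial gain over the pyridin-3-yl compound, an 8.3-fold lower number from compound 2 to compound 3 (0.92 log units; beyond the scatter), and this single step changes the ring, the linking atoms and the ring substituent together. The presence of a carbon-only ring is thus not enough to reach the level of the trifluoromethyl compound: compound 1 gives 190 nM, whereas compound 3 gives 17000 nM, with the linker and ring substituent both different. No measurement on hand accounts for this partial gain.

The compounds shown leave open how much of the remaining gap belongs to the oxygen linker and how much to methyl in place of trifluoromethyl. Also open, as far as these compounds go, is how an amine linker or a chlorine on the ring would read.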